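A fourth phosphate ester awaited after three measured ones

This account rests on a few compounds, and the source may have more. Where it says the series, first, only, none or still open, it means among the compounds named here.

Measured in a functional assay on Caco-2 cells (Homo sapiens) for cytotoxicity, read by MTT assay, with a stated time of 48 h; a higher number here means a weaker inhibitor, a lower number a stronger inhibitor:
compound 1, `O=C(O[C@H]1C[C@H](n2cc(F)c(=O)[nH]c2=O)O[C@@H]1COP(=O)(O)Oc1ccccc1)c1ccccc1`: 1020 nM
compound 2, `O=C(O[C@H]1C[C@H](n2cc(F)c(=O)[nH]c2=O)O[C@@H]1COP(=O)(O)Oc1cccnc1)c1ccccc1`: 2500 nM
compound 3, `O=C(O[C@H]1C[C@H](n2cc(F)c(=O)[nH]c2=O)O[C@@H]1COP(=O)(O)Oc1ccc2ncccc2c1)c1ccccc1`: 2460 nM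

Compound 2 carries the highest of the three numbers; its gap to compound 3 lies within the scatter, a 1.0-fold lower number from compound 2 to compound 3 (0.01 log units; within the scatter), whereas compound 1 sits beyond the scatter from it, a 2.5-fold higher number from compound 1 to compound 2 (0.39 log units; beyond the scatter). Compound 4, `C[n+]1cccc(OP(=O)([O-])OC[C@H]2O[C@@H](n3cc(F)c(=O)[nH]c3=O)C[C@@H]2OC(=O)c2ccccc2)c1`, differs from compound 2 in that (a group of 11 heavy atoms (6 carbon, 1 nitrogen, 3 oxygen, 1 phosphorus; one six-membered aromatic ring with 1 hetero atom) in place of a group of 10 heavy atoms (5 carbon, 1 nitrogen, 3 oxygen, 1 phosphorus; one six-membered aromatic ring with 1 hetero atom), on an oxygen on a saturated carbon). Among the measured compounds shown here, no measured step exchanges these two groups; the only steps seen replace one group on the oxygen by another, a 2.5-fold higher number from compound 1 to compound 2 (0.39 log units; beyond the scatter) and a 2.4-fold higher number from compound 1 to compound 3 (0.38 log units; beyond the scatter), both modest. The step expected for compound 4 is a 1.1-fold higher number from compound 2 to compound 4 (0.05 log units; within the scatter), keeping it near its parent. The estimate for compound 4 in this assay is 2800 nM, within 1200 nM to 6500 nM.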

Compound 4, half-maximal inhibitory concentration: 1380 nM
Beside the measured number, compound 4's estimate is 2.0-fold (0.31 log units) above it, and the stated range covers the measured number.
By their numbers in this assay, from the lowest: compounds 1, 4, 3 and 2 (each within the scatter of the next, the first and the last beyond it).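

In this assay the group of 11 heavy atoms on this oxygen gives a 1.8-fold lower number from compound 2 to compound 4 (0.26 log units; within the scatter) and a 1.4-fold higher number from compound 1 to compound 4 (0.13 log units; within the scatter) and so stands within the scatter of both compound 2 and compound 1, though those two lie beyond the scatter of each other. The earlier replacements of phenyl, in compound 2 and compound 3, both ended beyond the scatter from compound 1, and this one does not. Nothing available explains the result. As far as these compounds go, how an amine or a carboxylic acid on the ring of this group would read remains open.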